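Returning a Fused Bicyclic Amide to the Valine Core

The source may hold more compounds than are shown below. What is called first, only, known or untested is meant among the compounds shown, and "the series" means these compounds.

Three measured compounds share one core. Compound 1 `CC(C)[C@@H](NC(=O)c1cc2ccccc2s1)C(=O)N1CCC(c2ccc(Cl)cc2)CC1` carries a 1-benzothiophen-2-yl group on the carbonyl carbon of its amide; in an assay on THP-1 cells for displacement of a labelled ligand from C-C chemokine receptor type 1 (Homo sapiens) (on this read-out higher numbers stand for weaker inhibition and lower numbers for stronger inhibition), compound 1 gives 58 nM. Compound 2 `Cc1ccccc1CCC(=O)N[C@@H](C(=O)N1CCC(c2ccc(Cl)cc2)CC1)C(C)C` has 2-(2-methylphenyl)ethyl in that place and in this assay compound 2 gives 19 nM. Compound 3 `CC(C)CCC(=O)N[C@@H](C(=O)N1CCC(c2ccc(Cl)cc2)CC1)C(C)C` has isopentyl there, and in this assay compound 3 gives 26 nM. Compound 3 therefore holds the second highest number of the three: its nearest neighbour is compound 2, since a 1.4-fold higher number from compound 2 to compound 3 (0.14 log units; within the scatter), and its furthest is compound 1, since a 2.2-fold lower number from compound 1 to compound 3 (0.35 log units; beyond the scatter). The remaining step, a 3.1-fold lower number from compound 1 to compound 2 (0.48 log units; beyond the scatter), shows that both open-chain groups gave lower numbers than the fused bicyclic one.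

Compound 4 `CC(C)[C@@H](NC(=O)c1nc2ccccc2s1)C(=O)N1CCC(c2ccc(Cl)cc2)CC1` is the next compound: 1,3-benzothiazol-2-yl in place of isopentyl on a carbonyl carbon. Among the measured compounds shown here, the step that bears on this is the one from compound 1 to compound 3, which went to a lower number; putting a fused bicyclic aromatic group back on the same carbonyl carbon is expected to undo that, giving a modest rise. For the measured compounds named here, no measured pair compares 1,3-benzothiazol-2-yl with 1-benzothiophen-2-yl, so the range is kept wide. For compound 4 the expected step is a 1.9-fold higher number from compound 3 to compound 4 (0.28 log units; within the scatter). Compound 4 is estimated at 50 nM, between 20 nM and 150 nM.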

Compound 4, half-maximal inhibitory concentration: 18 nM
Compound 4: the middle estimate sits 2.8-fold (0.44 log units) above what was measured; measured number outside the range, below it.
By their numbers in this assay, from the lowest: compounds 4, 2 and 3 (each within the scatter of the next); then compound 1.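

The fused bicyclic group does not by itself raise the number at this carbonyl carbon: 1,3-benzothiazol-2-yl gives a 3.2-fold lower number from compound 1 to compound 4 (0.51 log units; beyond the scatter) in this assay, a change that leaves the two ring systems the same size and swaps one ring carbon for nitrogen. Compound 4 also cannot be told apart from the open-chain compounds, with a 1.4-fold lower number from compound 3 to compound 4 (0.16 log units; within the scatter) and a 1.1-fold lower number from compound 2 to compound 4 (0.02 log units; within the scatter), so three quite different groups now read alike here and compound 1 is the one that goes against this. The data give no reason why a single ring atom separates compound 1 from compound 4, and no measurement explains it.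

The compounds shown leave open whether nitrogen at that ring position is what matters, which a 1,3-benzoxazol-2-yl group, with oxygen in place of the sulfur, would help to test. They also say nothing about how a single phenyl ring, or a chain ending in an amine or a carboxylic acid, would read on the same carbonyl carbon.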